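Pyridyl-substituted bis(hydroxyphenyl) series: topoisomerase inhibition notes

The compounds below may be only part of what the source reports. "The series", "measured", "known", "first", "only" and "open" are said of these compounds alone.

Measured compounds:
- compound 1 `Oc1ccc(-c2cc(-c3ccco3)cc(-c3ccc(O)cc3)n2)cc1`: 0%
- compound 2 `Oc1ccc(-c2cc(-c3ccccn3)cc(-c3ccccc3O)n2)cc1`: "not determined" (no result reported)
- compound 3 `Oc1ccc(-c2cc(-c3ccccn3)cc(-c3ccc(O)cc3)n2)cc1`: "not determined" (no result reported)

In an assay on isolated protein for inhibition of DNA topoisomerase 1 (Homo sapiens), with a stated time of 30 min, tested at 20 uM (a higher number here means a stronger effect of the compound at the concentration tested, a lower number a weaker effect), compound 1 gives 0%. For compound 2 no number was obtained, the result being "not determined" (no result reported). Compound 3 likewise stands without a number in this assay, its entry reading "not determined" (no result reported), so no measured anchor exists for the step that follows.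

Compound 4 `Oc1ccc(-c2cc(-c3cccnc3)cc(-c3ccc(O)cc3)n2)cc1` differs from compound 3 in one place: pyridin-3-yl in place of pyridin-2-yl on an aromatic carbon. Within the data shown here, with the only number being that of compound 1 at 0%, no step beyond the usual scatter is anticipated for this change in this assay, in either direction. Compound 4 is therefore expected to give about 5%, with a range from 0% to 25%.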

Compound 4, a percentage reported as inhibition, at one concentration (the size of the read-out at that concentration, not a potency): 5%
Compound 4: middle estimate and measured number agree at the digits printed; low and high end bracket the measured number.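

In this assay, pyridin-3-yl in place of furan-2-yl, on the aromatic carbon opposite the ring nitrogen, gives a number 5 percentage points higher from compound 1 to compound 4 (within the scatter), so this swap does not separate the two groups at this position. The step from compound 3 to compound 4 cannot be read, as compound 3 has no number. Nothing available bears on the reason for this result.

Still open, from the compounds shown here alone, is whether an amine or a carboxylic acid on this carbon would give a step beyond the scatter. Going by these compounds, the standing of pyridin-2-yl against pyridin-3-yl also remains open.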